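The compounds below may be only part of what the source reports. "The series", "measured", "known", "first", "only" and "open" are said of these compounds alone.

Of the compounds shown here, two sharing one core have been measured so far in a functional assay on PANC-1 cells (Homo sapiens), read by microscopy, crystal violet staining and transwell migration, with a stated time of 18 h, in the presence of a further agent that is not named here; on this read-out lower numbers stand for stronger inhibition and higher numbers for weaker inhibition. Compound 1 `COc1ccc(-c2ncnn2-c2cccc(C(=O)NCCCCc3ccccc3)c2)cc1`, with hydrogen on the aromatic carbon in question, reaches only a limit, > 20000 nM. Among the measured compounds shown here, compound 2 `CCCCc1nc(-c2ccc(OC)cc2)n(-c2cccc(C(=O)NCCCCc3ccccc3)c2)n1`, with butyl at that place, gives 16800 nM, the only actual number available in this assay. Compound 3 `COc1ccc(-c2nc(C3CC3)nn2-c2cccc(C(=O)NCCCCc3ccccc3)c2)cc1` has cyclopropyl in place of butyl on that aromatic carbon, which lies between two ring nitrogen atoms (cyclopropyl in place of butyl on an aromatic carbon). For the measured compounds named here, one measured step bears on this place, namely an at least 1.1-fold lower number from compound 1 to compound 2 (0.07 log units; that floor lies within the scatter). From the compounds shown here alone, that step involves a limit and shows no change beyond the scatter, so no step beyond the scatter is expected in this assay, and the direction remains open. The estimated change is a 1.1-fold higher number from compound 2 to compound 3 (0.03 log units; within the scatter). Compound 3 is expected at 18000 nM, with an estimated range of 9000 nM to 32000 nM.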

Compound 3, half-maximal inhibitory concentration: 7680 nM
Estimate against measurement, compound 3: 2.3-fold (0.37 log units) above; measured number outside the range, below it.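

In this assay, the aromatic carbon between two ring nitrogen atoms now shows a real response to the group it carries, which the earlier step could not establish: the swap of butyl for cyclopropyl gives a 2.2-fold lower number from compound 2 to compound 3 (0.34 log units; beyond the scatter). Set against hydrogen, cyclopropyl also gives a step beyond the scatter, an at least 2.6-fold lower number from compound 1 to compound 3 (0.41 log units; beyond the scatter), whereas butyl in place of hydrogen did not clearly do so. Compound 1 reaches only a limit, so this step is a floor and its full size is unknown: the limit of > 20000 nM in this assay, at which 1 of the 3 values shown sits.

The compounds shown do not separate the presence of the three-membered ring from the smaller number of carbon atoms, a distinction that a propyl or cyclobutyl group at this carbon would address. They also leave open how an amine or a carboxylic acid would behave there.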